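Amide variation on a spiro core: estimate for compound 4

The source may report more compounds than this note shows. Statements on the series, on what has been measured and on what is new or still open speak of the compounds shown alone.

Measured so far in an assay on HEK293 cells for displacement of a labelled ligand from NPC1-like intracellular cholesterol transporter 1 (Homo sapiens); on this read-out lower numbers stand for stronger inhibition and higher numbers for weaker inhibition:
compound 1 `CC(C)(C)c1ccc(C(=O)N2CCC3(CC2)C(=O)N(CC(=O)N2CCC(CCO)CC2)CN3c2ccccc2)cc1`: 2600 nM
compound 2 `CC(C)(C)OC(=O)NC1CCN(C(=O)CN2CN(c3ccccc3)C3(CCN(C(=O)c4ccc(C(C)(C)C)cc4)CC3)C2=O)CC1`: 8300 nM
compound 3 `CCOC(=O)C1CCN(C(=O)CN2CN(c3ccccc3)C3(CCN(C(=O)c4ccc(C5CCCCC5)cc4)CC3)C2=O)CC1`: 900 nM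

Compound 1 gives the second highest of the three numbers in this assay. Its nearest neighbour is compound 3, whose value in this assay is 900 nM; compound 3 differs from compound 1 in two places at once, so no single step can be read from that pair. Within the data shown here, the one step that bears on the change in hand is a 3.2-fold higher number from compound 1 to compound 2 (0.50 log units; beyond the scatter), which introduced the tert-butoxycarbonyl-bearing group and raised the number beyond the scatter.

Compound 4 `CC(C)(C)OC(=O)NCCNC(=O)CN1CN(c2ccccc2)C2(CCN(C(=O)c3ccc(C(C)(C)C)cc3)CC2)C1=O` carries the change ((2-((tert-butoxycarbonyl)amino)ethyl)amino in place of 4-(2-hydroxyethyl)piperidin-1-yl on a carbonyl carbon). It keeps the tert-butoxycarbonyl amino piece seen in compound 2 but opens the six-membered ring into a chain. Given the rise seen in the step from compound 1 to compound 2, a step of similar size and direction is expected here, with wide uncertainty since ring opening itself has no measured precedent in the series; the expected step is a 2.3-fold higher number from compound 1 to compound 4 (0.36 log units; beyond the scatter). Compound 4 is therefore estimated at 6000 nM, within 2000 nM to 18000 nM.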

Compound 4, half-maximal inhibitory concentration: 10900 nM
Compound 4: middle estimate off by 1.8-fold (0.26 log units), on the low side; the range from low to high includes it.
By their numbers in this assay, from the lowest: compound 3; then compound 1; then compounds 2 and 4 (each within the scatter of the next).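

In this assay, (2-((tert-butoxycarbonyl)amino)ethyl)amino in place of 4-(2-hydroxyethyl)piperidin-1-yl on the carbonyl carbon gives a 4.2-fold higher number from compound 1 to compound 4 (0.62 log units; beyond the scatter) and is the second replacement at this position to raise the number beyond the scatter. Compound 2 keeps a six-membered ring here and compound 4 has no ring, yet compound 2 at 8300 nM and compound 4 at 10900 nM lie within the scatter of each other. Across these compounds, the higher number therefore accompanies the tert-butoxycarbonyl amino piece with or without the ring.

From the compounds shown here alone, whether that piece itself carries the rise stays open, and a free amine or a carboxylic acid at the end of the ethyl chain would help separate it from the loss of the 2-hydroxyethyl piperidine. Nothing available explains the rise.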